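Aryl Sulfonamide Swap at the Sulfonyl Sulfur

The source may hold more compounds than are shown below. What is called first, only, known or untested is meant among the compounds shown, and "the series" means these compounds.

Measured compounds:
compound 1, `Nc1ncnc(N2CC[C@@]3(CCCN(C[C@H](O)CNS(=O)(=O)c4ccccc4F)C3)C2)c1C1CC1`, 14000 nM
compound 2, `Nc1ncnc(N2CC[C@@]3(CCCN(C[C@H](O)CNS(=O)(=O)c4ccccc4Br)C3)C2)c1C1CC1`, 2000 nM

In an assay on LNCaP cells for inhibition of RAC-alpha serine/threonine-protein kinase (Homo sapiens) (a lower number here means a stronger inhibitor, a higher number a weaker inhibitor), compound 2 has the lower of the two numbers; the step of a 7.0-fold lower number from compound 1 to compound 2 (0.85 log units; beyond the scatter) separates it from compound 1. Compound 3, `Cc1ccc(S(=O)(=O)NC[C@@H](O)CN2CCC[C@@]3(CCN(c4ncnc(N)c4C4CC4)C3)C2)c(C)c1`, differs from compound 2 by 2,4-dimethylphenyl in place of 2-bromophenyl on a sulfonyl sulfur. Among the measured compounds shown here, no measured step covers this exact change; the only related one, a 7.0-fold lower number from compound 1 to compound 2 (0.85 log units; beyond the scatter), concerns the same position but a different group, so it bears on compound 3 only indirectly. The author expects compound 3 to stay close to compound 2, with a step of a 1.3-fold lower number from compound 2 to compound 3 (0.12 log units; within the scatter) that may not exceed the scatter. Compound 3 is estimated at 1500 nM, within 400 nM to 6000 nM.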

Compound 3, half-maximal inhibitory concentration: 18000 nM
Compound 3: middle estimate off by 12-fold (1.08 log units), on the low side; the measured number lies above the stated range.
By their numbers in this assay, from the lowest: compound 2; then compounds 1 and 3 (each within the scatter of the next).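

In this assay the lower number seen with 2-bromophenyl on the sulfonyl sulfur does not carry over to 2,4-dimethylphenyl (a 9.0-fold higher number from compound 2 to compound 3 (0.95 log units; beyond the scatter)), and the step from the 2-fluorophenyl compound stays within the scatter (a 1.3-fold higher number from compound 1 to compound 3 (0.11 log units; within the scatter)). Among these three aryl groups only 2-bromophenyl stands apart, so a substituted phenyl alone does not bring the lower number. Nothing given here accounts for this difference. As far as these compounds go, whether a chlorophenyl, a plain phenyl or a pyridine ring would read like compound 2 or like compound 3 remains open.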